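This account rests on a few compounds, and the source may have more. Where it says the series, first, only, none or still open, it means among the compounds named here.

Compound 1 `Nc1ncnc2c1c(Oc1cc(C(F)(F)F)ccn1)nn2[C@H]1C[C@H](F)C1` has been measured in an ADME assay on microsomes from liver (Homo sapiens) for metabolic stability, read by LC-MS, using NADPH, with a stated time of 10 min, tested at 10 uM (on this read-out lower numbers stand for a shorter-lived compound and higher numbers for a longer-lived compound), where compound 1 gives 2.03 h. Compound 3 `Nc1ncnc2c1c(Oc1cc(Cl)ccn1)nn2[C@H]1C[C@H](F)C1` gives 0.833 h in this assay. Compound 2 `CC(C)(C)n1nc(Oc2cc(C#N)ccn2)c2c(N)ncnc21` gives only a limit of this assay, > 2.41 h, so no plain number is known for it. Among the two plain numbers, compound 1 stands highest; the nearest number belongs to compound 3, reached by a 2.4-fold lower number from compound 1 to compound 3 (0.39 log units; beyond the scatter), a modest step.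

Compound 4 `CO[C@H]1CC[C@@H](n2nc(Oc3cc(C(F)(F)F)ccn3)c3c(N)ncnc32)CC1` has not yet been measured. It differs from compound 1 in one place: 4-methoxycyclohexyl in place of 3-fluorocyclobutyl on an aromatic nitrogen. Within the data shown here, the only measured step, a 2.4-fold lower number from compound 1 to compound 3 (0.39 log units; beyond the scatter), concerns a different place, the aromatic carbon that carries chloro or trifluoromethyl, so it offers no direct guide to a change on the aromatic nitrogen. Among the measured compounds shown here, with no step of the same kind to lean on, the expectation for compound 4 is a number close to that of compound 1, with no change beyond the scatter, though with wide uncertainty. Compound 4 is therefore estimated at 1.6 h, between 0.6 h and 3.5 h. This estimate means an expected step of a 1.3-fold lower number from compound 1 to compound 4 (0.10 log units; within the scatter).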

Compound 4, half-life: 0.317 h
Compound 4: middle estimate off by 5.0-fold (0.70 log units), on the high side; measured number below the stated range.
By their numbers in this assay, from the lowest: compound 4; then compound 3; then compound 1. At a limit, above all of these: compound 2.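

With a 6.4-fold lower number from compound 1 to compound 4 (0.81 log units; beyond the scatter) in this assay the group on the aromatic nitrogen proves able to move the half-life, something the earlier step at the aromatic carbon (a 2.4-fold lower number from compound 1 to compound 3 (0.39 log units; beyond the scatter)) could not show. This single change alters several things at once: the ring grows from four-membered to six-membered, the fluorine leaves and a methoxy oxygen enters, so the step cannot be assigned to any one of them. Nothing measured here points to a cause for the shorter half-life.

Open, going by these compounds, is whether plain cyclohexyl, or a cyclohexyl carrying a hydroxyl or an amine in place of the methoxy, would behave like 4-methoxycyclohexyl or like 3-fluorocyclobutyl. Also open, on these data alone, is whether a plain cyclobutyl would keep the half-life of compound 1 without its fluorine.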